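Carboxy in place of hydroxy: a step without precedent

The source may report more compounds than this note shows. Statements on the series, on what has been measured and on what is new or still open speak of the compounds shown alone.

Compound 1 `CCOc1ccc2nc(C(=O)Nc3c(F)cc(-c4cccc(F)c4)cc3F)c(C)c(O)c2c1` was tested in a functional assay on Hep 3B2 cells (Homo sapiens) for antiproliferative activity, read by MTT assay, with a stated time of 24 h, tested at 0.41 ug/mL (a lower number here means a weaker effect, a higher number a stronger effect of the compound at the concentration tested), and gave 0.26%. Among the three compounds measured it stands lowest, though both neighbours lie within the scatter: compound 2 `Cc1c(C(=O)Nc2c(F)cc(-c3cccc(F)c3)cc2F)nc2ccc(OC(F)(F)F)cc2c1O` gives 5.62% and compound 3 `Cc1c(C(=O)Nc2c(F)cc(-c3cccc(F)c3)cc2F)nc2ccc(C(F)(F)F)cc2c1O` gives 9.38%. The measured steps, a number 5.4 percentage points higher from compound 1 to compound 2 (within the scatter), a number 9.1 percentage points higher from compound 1 to compound 3 (within the scatter) and a number 3.8 percentage points higher from compound 2 to compound 3 (within the scatter), all concern a different position on the shared core and none left the scatter. Compound 4 `CCOc1ccc2nc(C(=O)Nc3c(F)cc(-c4cccc(F)c4)cc3F)c(C)c(C(=O)O)c2c1` differs from compound 1 by carboxy in place of hydroxy on an aromatic carbon. Within the data shown here, no measured step touches this change, so nothing here supports a move beyond the scatter. Compound 4 is therefore expected to show only a number 1.7 percentage points higher from compound 1 to compound 4 (within the scatter). Compound 4 is estimated at 2%, ranging from -5% to 12%.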

Compound 4, a percentage reported as inhibition, at one concentration (the size of the read-out at that concentration, not a potency): 5.34%
Compound 4: the middle estimate sits 3.3 percentage points below what was measured, within the range that was stated.
By their numbers in this assay, from the lowest: compounds 1, 4, 2 and 3 (each within the scatter of the next).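

In this assay the exchange on the aromatic carbon opposite the ring nitrogen shows a number 5.1 percentage points higher from compound 1 to compound 4 (within the scatter) and so does not leave the scatter. Among these compounds, this position therefore tolerates carboxy in place of hydroxy, with two more heavy atoms, without a readable change at the concentration tested, as the earlier steps at a different position also stayed within the scatter. No evidence here bears on why this exchange leaves the read-out unmoved. Going by these compounds, whether an amine or a methoxy group on this aromatic carbon would leave the scatter remains open. So does whether carboxy would behave alike on the cores of compound 2 and compound 3.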